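From pyridin-2-yl to pyridin-4-yl on compound 3

The compounds below may be only part of what the source reports. "The series", "measured", "known", "first", "only" and "open" are said of these compounds alone.

Of the compounds shown here, three sharing much of their structure have been measured in a physicochemical assay for solubility, read by HPLC, in simulated intestinal fluid, with a stated time of 16 h, tested at 125 ug/mL; on this read-out lower numbers stand for lower solubility and higher numbers for higher solubility. There, compound 1 `CNC(=O)c1cc(C(=O)NC2CC2)cn(Cc2ccc(OC)cc2)c1=O` gives 263 ug/mL, compound 2 `CNC(=O)c1cc(C(=O)NC2CC2)c(C)n(Cc2ccccc2)c1=O` gives 577 ug/mL, and compound 3 `CNC(=O)c1cc(C(=O)NC2CCC2)cn(Cc2ccccn2)c1=O` gives 920 ug/mL. Compound 3 stands higher than compound 1 by a gap beyond the usual scatter of repeat measurements, whereas compound 2 and compound 3 lie within that scatter of each other and cannot be told apart.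

The next compound is compound 4 `CNC(=O)c1cc(C(=O)NC2CCC2)cn(Cc2ccncc2)c1=O`, which has the same atoms as compound 3, joined differently: pyridin-4-yl in place of pyridin-2-yl on a saturated chain carbon bound to an aromatic nitrogen. Put simply, pyridin-4-yl takes the place of pyridin-2-yl on a saturated chain carbon bound to an aromatic nitrogen.

Among the measured compounds shown here, no two measured compounds differ in only one place, so the data offer no direct precedent for this swap. With no such evidence, no step beyond the scatter is expected in this assay, and the starting point is compound 3 at 920 ug/mL. The expected change, a 1.3-fold lower number from compound 3 to compound 4 (0.12 log units; within the scatter), is small and stays within the scatter. For compound 4 the estimated value is 700 ug/mL, with an expected range from 350 ug/mL to 1300 ug/mL.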

Compound 4, solubility: 121 ug/mL
Compound 4: middle estimate off by 5.8-fold (0.76 log units), on the high side; measured number outside the range, below it.
By their numbers in this assay, from the lowest: compound 4; then compound 1; then compounds 2 and 3 (each within the scatter of the next).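

Among the compounds shown here, this pair gives the first direct reading at this position in this assay: the swap produces a 7.6-fold lower number from compound 3 to compound 4 (0.88 log units; beyond the scatter), a step beyond the usual scatter. Pyridin-2-yl and pyridin-4-yl have the same heavy atoms, the same hydrogen-bond counts and no net charge, so on a saturated chain carbon bound to an aromatic nitrogen, counting these features would not have separated compound 3 from compound 4, yet their solubility numbers clearly differ. Nothing measured here accounts for the size or direction of this step.

For the compounds shown here, with only this pair carrying the swap, it remains open whether a similar step would appear with other groups elsewhere on the shared core, such as the cyclopropyl amide of compound 1 and compound 2 in place of the cyclobutyl amide of compound 3 and compound 4. Also open, on these data alone, is where an amine or a carboxylic acid on that same saturated chain carbon would fall in this assay relative to compound 3 and compound 4.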